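Thiosemicarbazone series: aryl exchange on compound 3

The compounds below may be only part of what the source reports. "The series", "measured", "known", "first", "only" and "open" are said of these compounds alone.

Measured so far:
Compound 1 `O=C1Nc2ccc(Br)cc2/C1=N/NC(=S)N/N=C/c1c(Cl)cccc1Cl`; in a functional assay on HeLa cells (Homo sapiens) for inhibition, read by MTT assay (on this read-out lower numbers stand for stronger inhibition and higher numbers for weaker inhibition), compound 1 gives 3530 nM.
Compound 2 `Cc1ccc(O)c(/C=N/NC(=S)N/N=C2\C(=O)Nc3ccc(Br)cc32)c1`; in this assay compound 2 reaches only the limit > 50000 nM.
Compound 3 `Cc1ccc2c(c1)/C(=N/NC(=S)N/N=C/c1c(Cl)cccc1Cl)C(=O)N2`; in this assay compound 3 gives 1790 nM.

Compound 3 holds the lowest of the two numbers given. Its nearest neighbour is compound 1, separated by a 2.0-fold lower number from compound 1 to compound 3 (0.29 log units; within the scatter), which is within the scatter, so the two cannot be ordered. Compound 2 sits at the limit of > 50000 nM in this assay, at which 1 of the 3 values shown sits.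

Compound 4 `Cc1ccc2c(c1)/C(=N/NC(=S)N/N=C/c1ccc(Br)cc1)C(=O)N2` differs from compound 3 in one place: 4-bromophenyl in place of 2,6-dichlorophenyl on a carbon with a double bond to nitrogen. Going by the values given here, the one measured step at this position is an at least 14-fold higher number from compound 1 to compound 2 (1.15 log units; beyond the scatter), a large loss, although the group that entered there was not 4-bromophenyl. The step of a 2.0-fold lower number from compound 1 to compound 3 (0.29 log units; within the scatter) lies at the other end of the shared core and says little about this exchange. Among the compounds with values here, exchanging the 2,6-dichlorophenyl has so far only been seen to weaken inhibition, so a move toward a higher number is expected, of the size a 3.4-fold higher number from compound 3 to compound 4 (0.53 log units; beyond the scatter), with the wide range reflecting that only one such exchange has been measured. For compound 4 in this assay the estimate is 6000 nM, expected to lie between 1500 nM and 30000 nM.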

Compound 4, half-maximal inhibitory concentration: > 50000 nM
Compound 4: a limit, no number; the forecaster's own chance of this, stated with the estimate: 20%; at least 8.3-fold (0.92 log units) between middle value and limit.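

In this assay, the exchange gives an at least 27-fold higher number from compound 3 to compound 4 (1.44 log units; beyond the scatter), so a large loss on leaving 2,6-dichlorophenyl is now seen on a second version of the shared core and with a second entering group. This loss comes without a change in the counts compared: 2,6-dichlorophenyl and 4-bromophenyl each have one six-membered aromatic ring of carbon only, no hydrogen-bond donors or acceptors and no net charge, so the earlier loss with 2-hydroxy-5-methylphenyl no longer stands alone. Neither exchange at this position goes against the pattern of weaker inhibition, but both end at a limit of the assay rather than at a number, so the full size of each loss stays unknown: the limit of > 50000 nM in this assay, at which 2 of the 4 values shown sit.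

The change from 2,6-dichlorophenyl to 4-bromophenyl alters both the halogen and its placement on the ring, and the compounds shown do not separate these two changes. On these data alone, it remains open whether an unsubstituted phenyl, or a phenyl carrying an amine or a carboxylic acid, would give a measurable number at this position.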